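Series notes: furan-3-yl in place of the alkenyl group

A few compounds are considered here, and "the series" means these few. Any claim that something is new, unique, unknown or untested is made for them only; others in the source may bear on it.

Compound 1 `CC(C)=CC(O)C1=CC(=O)c2ccccc2C1=O` gives 5200 nM in a functional assay on WHCO1 cells (Homo sapiens) for cytotoxicity, read by MTT assay, with a stated time of 24 h; on this read-out higher numbers stand for weaker inhibition and lower numbers for stronger inhibition. Going by the values given here, of the three numbers measured so far this is the second highest: compound 3 `O=C1C=C(C(O)c2cccc3ccccc23)C(=O)c2ccccc21` gives a lower number, 2400 nM, and compound 2 `Cc1cc(Cl)ccc1C(=O)C1=CC(=O)c2ccccc2C1=O` a higher one, 50400 nM, both gaps beyond the usual scatter. Compound 4 `O=C1C=C(C(O)c2ccoc2)C(=O)c2ccccc21` has not yet been measured in this assay. It differs from compound 1 in one place: furan-3-yl in place of 2-methylprop-1-en-1-yl on a saturated chain carbon bound to a double-bonded ring carbon and an oxygen on a saturated carbon. Among the compounds with values here, no measured pair matches this change, so its size can only be guessed; compound 3, which also carries an aromatic ring at that carbon, gives 2400 nM. The step is expected to be a 1.3-fold lower number from compound 1 to compound 4 (0.11 log units; within the scatter), small and toward lower numbers, possibly within the scatter. Compound 4 is estimated at 4000 nM, in the range 1500 nM to 11000 nM.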

Compound 4, half-maximal inhibitory concentration: 10900 nM
For compound 4 the middle estimate is 2.7-fold (0.44 log units) below the measured one; the range from low to high includes it.
By their numbers in this assay, from the lowest: compound 3; then compound 1; then compound 4; then compound 2.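

In this assay, the swap at this carbon gives a 2.1-fold higher number from compound 1 to compound 4 (0.32 log units; beyond the scatter) and so shows that the position is sensitive to the group it carries: furan-3-yl does not simply stand in for 2-methylprop-1-en-1-yl. Going by these compounds alone, the step is modest, but it is the first one read at this place and it points toward a higher number. Nothing on hand explains it.

From the compounds shown here alone, whether a saturated group such as cyclohexyl would behave like either of these remains open. So does the effect of an aminomethyl group on a phenyl ring at this carbon.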